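This account rests on a few compounds, and the source may have more. Where it says the series, first, only, none or still open, it means among the compounds named here.

Compound 3 `O=C1N(CCCCCCCOc2ccc(Cl)cc2)CCN1c1ccncc1` is known in a functional assay on cells (Homo sapiens) for cytotoxicity (on this read-out higher numbers stand for lower toxicity in this test and lower numbers for higher toxicity in this test), only as a limit: in this assay compound 3 gives > 25000 nM. Compound 1 `O=C1N(CCCCCCOc2ccc(C(F)(F)F)cc2)CCN1c1ccncc1` also returns a limit, giving > 25000 nM. Compound 2 `O=C1N(CCCCCCCOc2ccc(Br)cc2)CCN1c1ccncc1` likewise sits at a limit, with > 25000 nM. Among the measured compounds shown here, since the limit of > 25000 nM in this assay, at which 3 of the 3 values shown sit, covers every value shown, the one measured step, a step that the two limits leave unreadable from compound 2 to compound 3, cannot be read for size or direction. Compound 4 `Cc1ccc(OCCCCCCN2CCN(c3ccncc3)C2=O)cc1` carries 4-methylphenoxy in place of (4-chlorophenoxy)methyl on a saturated chain carbon, six bonds along the chain from an amide-type nitrogen in a ring. No readable step bears on this change, so no shift beyond the scatter is expected in either direction. The estimate for compound 4 in this assay is 25000 nM, range 10000 nM to 60000 nM. The expected step is a number no higher from compound 3 to compound 4 (the limit leaves the size open), and a limit rather than a number is the most likely outcome.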

Compound 4, half-maximal cytotoxic concentration: > 25000 nM
Compound 4 gave a limit, no number; the forecaster's own chance of this, stated with the estimate: 80%; the middle value lies on the limit itself.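

The steps from compound 1, compound 2 and compound 3 to compound 4 cannot be read for size or direction, as all four compounds give a limit: the limit of > 25000 nM in this assay, at which 4 of the 4 values shown sit. The compounds shown leave open whether any of these changes moves the read-out at all.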